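Swapping a urea cap for a plain alkyl chain

The compounds below may be only part of what the source reports. "The series", "measured", "known", "first", "only" and "open" are said of these compounds alone.

Compound 1 `CN(C)C(=O)N1CCC[C@H]1C(=O)N1CCC(NS(=O)(=O)c2cc(S(=O)(=O)c3ccccc3)ccc2C(F)(F)F)CC1` and compound 2 `O=C([C@@H]1CCCN1C(=O)N1CCOCC1)N1CCC(NS(=O)(=O)c2cc(S(=O)(=O)c3ccccc3)ccc2C(F)(F)F)CC1` share one core and differ only at the nitrogen of the five-membered ring, which carries a urea carbonyl in both. In a functional assay on U2OS cells for antagonist activity at proto-oncogene Wnt-3 (Homo sapiens), read by a luciferase reporter, with a stated time of 18 h (a higher number here means that more compound is needed for the effect, a lower number that less compound is needed), compound 1 gives 160 nM, and in this assay compound 2 gives 280 nM. The step of a 1.8-fold higher number from compound 1 to compound 2 (0.24 log units; within the scatter) is the only measured one, and it stays within the scatter. Compound 2 therefore stands as the higher of the two numbers, but not in a way that can be told apart from compound 1.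

Compound 3 `CC(C)(C)CCN1CCC[C@H]1C(=O)N1CCC(NS(=O)(=O)c2cc(S(=O)(=O)c3ccccc3)ccc2C(F)(F)F)CC1` is the next compound. Its change from compound 2 is 3,3-dimethylbutyl in place of (morpholin-4-yl)carbonyl on an amine nitrogen in a ring. The measured step touched only the group on the carbonyl, whereas here the carbonyl itself leaves and a chain with no acceptors enters, so that step bears on this one only weakly. Among the compounds with values here, with no direct precedent, the expectation for compound 3 is a number in this assay near compound 2, with a wide range, as the step of a 1.6-fold higher number from compound 2 to compound 3 (0.21 log units; within the scatter); the estimate for compound 3 is 450 nM, between 120 nM and 2500 nM.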

Compound 3, half-maximal effective concentration: 450 nM
Estimate against measurement, compound 3: no gap at the digits printed; measured number inside the range.
By their numbers in this assay, from the lowest: compounds 1, 2 and 3 (each within the scatter of the next, the first and the last beyond it).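

Replacing (morpholin-4-yl)carbonyl with 3,3-dimethylbutyl on the amine nitrogen of the five-membered ring removes the carbonyl, a whole ring and both hydrogen-bond acceptors of that group, yet it gives a 1.6-fold higher number from compound 2 to compound 3 (0.21 log units; within the scatter) in this assay and so no difference that can be told apart from compound 2. Set against the dimethylcarbamoyl group of compound 1, the same chain gives a 2.8-fold higher number from compound 1 to compound 3 (0.45 log units; beyond the scatter) and this modest step is the first here to pass the scatter, so the result depends on which urea serves as the comparison, and the carbonyl is shown not to be required for a measurable effect at this position. Nothing measured here accounts for this tolerance of an all-carbon chain.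

The compounds shown leave open how the number responds to the size of the chain, for example whether a short ethyl group or a longer unbranched octyl chain would stay close to compound 3. They also leave open whether a chain ending in an amine or a carboxylic acid would be accepted on this nitrogen.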